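A few compounds are considered here, and "the series" means these few. Any claim that something is new, unique, unknown or untested is made for them only; others in the source may bear on it.

Measured in a functional assay on KB cells (Homo sapiens) for inhibition, read by sulforhodamine B assay; on this read-out higher numbers stand for weaker inhibition of growth and lower numbers for stronger inhibition of growth:

- Compound 1 `c1ccc(-c2ccc(-c3ccc(-c4nc5ccccc5[nH]4)cc3)cc2)cc1` gives 39700 nM
- Compound 2 `Cc1ccc2[nH]c(-c3ccc(-c4ccc(-c5cccc(Cl)c5)cc4)cc3)nc2c1` gives 2260 nM
- Compound 3 `FC(F)(F)c1ccc(-c2ccc(-c3ccc(-c4nc5ccccc5[nH]4)cc3)cc2)cc1` gives 47200 nM

Compound 1 stands close to compound 3, and the two lie within the scatter of each other, while compound 2 shows a clearly lower number in this assay. Compound 4 `COc1ccc(-c2ccc(-c3ccc(-c4nc5ccccc5[nH]4)cc3)cc2)cc1` has not yet been measured. It carries methoxy in place of hydrogen on an aromatic carbon, so that phenyl becomes 4-methoxyphenyl.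

Within the data shown here, the one measured step that bears on this change is the replacement of hydrogen by trifluoromethyl, a 1.2-fold higher number from compound 1 to compound 3 (0.08 log units; within the scatter), which stays within the scatter. Among the measured compounds shown here, compound 2 differs from compound 1 in more than one place and offers no single step. On the evidence of compound 3 alone, no shift beyond the scatter is expected, although one step is thin support. The expected step is a 1.1-fold lower number from compound 1 to compound 4 (0.05 log units; within the scatter). For compound 4 the estimated value is 35000 nM. The expected range for compound 4 runs from 15000 nM to 70000 nM.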

Compound 4, concentration for 50% growth inhibition: 47200 nM
Estimate against measurement, compound 4: 1.3-fold (0.13 log units) below; low and high end bracket the measured number.
By their numbers in this assay, from the lowest: compound 2; then compounds 1, 3 and 4 (each within the scatter of the next).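

In this assay, methoxy on an aromatic carbon, para to a large group, brings a 1.2-fold higher number from compound 1 to compound 4 (0.08 log units; within the scatter), so a second group at this place, one that adds an oxygen, leaves the number within the scatter of the unsubstituted phenyl. Exchanging one substituent for the other at the same carbon brings no change at the digits printed from compound 3 to compound 4 (within the scatter), which means that methoxy and trifluoromethyl cannot be told apart here, and the position has so far tolerated both without a shift beyond the scatter. No measurement shown offers a reason for this flat result.

As far as these compounds go, whether an amine or a carboxylic acid at this carbon would move the number beyond the scatter remains open. Also open, from the compounds shown here alone, is whether methoxy on another carbon of this ring would behave as it does here.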